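Notes on chloro placement in an aryl adenosine series

This account rests on a few compounds, and the source may have more. Where it says the series, first, only, none or still open, it means among the compounds named here.

compound 1 `CN1CCN(c2nc(-c3ccc(Cl)c(Cl)c3)nc3[nH]cnc23)CC1` — 24.1%
compound 2 `CN1CCN(c2nc(-c3cccc(Cl)c3)nc3[nH]cnc23)CC1` — 29.9%
compound 3 `Clc1ccc(-c2nc(N3CCCCC3)c3nc[nH]c3n2)cc1` — 1.4%

In an assay on cells for displacement of a labelled ligand from adenosine receptor A2b (Homo sapiens), read by scintillation counting and radioligand binding, with a stated time of 30 min, tested at 10 uM (on this read-out lower numbers stand for less inhibition and higher numbers for more inhibition at the one concentration tested (going by the name of the read-out)), compound 2 holds the highest of the three numbers, with compound 1 nearest and within the scatter of it and compound 3 far below, beyond the scatter. Going by the values given here, the only measured step that bears on the present question is a number 5.8 percentage points higher from compound 1 to compound 2 (within the scatter), a hydrogen in place of chloro on an aromatic carbon. Compound 4 `CN1CCN(c2nc(-c3cc(Cl)ccc3Cl)nc3[nH]cnc23)CC1` has not yet been measured; against compound 2 its difference is chloro in place of hydrogen on an aromatic carbon. Little movement is expected because a number 5.8 percentage points higher from compound 1 to compound 2 (within the scatter) stayed within the scatter when a chloro was exchanged on the same ring, so the expected step is a number 4.9 percentage points lower from compound 2 to compound 4 (within the scatter). Compound 4 is estimated at 25% in this assay, with a range from 8% to 42%.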

Compound 4, a percentage reported as inhibition, at one concentration (the size of the read-out at that concentration, not a potency): 13%
The estimate for compound 4 lay 12 percentage points above the measured number, within the range that was stated.
By their numbers in this assay, from the lowest: compound 3; then compound 4; then compounds 1 and 2 (each within the scatter of the next).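

In this assay, a chloro ortho to a large group and para to a chloro group moves the number beyond the scatter (a number 16.9 percentage points lower from compound 2 to compound 4 (beyond the scatter)), which the earlier chloro exchange on this ring did not do (a number 5.8 percentage points higher from compound 1 to compound 2 (within the scatter)). With the chloro count held at two, 2,5-dichlorophenyl in place of 3,4-dichlorophenyl also gives a modest step (a number 11.1 percentage points lower from compound 1 to compound 4 (beyond the scatter)), so placement matters here, not the count alone. Nothing at hand accounts for this drop. Going by these compounds, whether a methoxy or a fluoro at the same place would give a similar step stays open.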